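A thiazolyl swap on the sulfonamide of compound 2

The compounds below may be only part of what the source reports. "The series", "measured", "known", "first", "only" and "open" are said of these compounds alone.

Among the compounds with values here, in a physicochemical assay for lipophilicity (on this read-out lower numbers stand for lower lipophilicity and higher numbers for higher lipophilicity), compound 2 (`Cc1nc(-c2cc(C(F)(F)F)ccc2[C@H]2CCOc3cc(S(=O)(=O)Nc4cccc(F)n4)ccc32)co1`) gives 4 and stands highest of the three compounds measured so far. Compound 3 (`Cn1nccc1-c1cc(C(F)(F)F)ccc1[C@H]1CCOc2cc(S(=O)(=O)Nc3cccc(F)n3)ccc21`) follows with 3.6 and compound 1 (`O=S(=O)(Nc1ncccn1)c1ccc2c(c1)OCC[C@@H]2c1ccc(C(F)(F)F)cc1-c1ccc(F)nc1`) lies furthest down with 2.8 on the same scale.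

Compound 4 (`Cc1nc(-c2cc(C(F)(F)F)ccc2[C@H]2CCOc3cc(S(=O)(=O)Nc4nccs4)ccc32)co1`) has not yet been measured. It differs from compound 2 in one place, with 1,3-thiazol-2-yl in place of 6-fluoropyridin-2-yl on a sulfonamide nitrogen. One six-membered aromatic ring with 1 hetero atom thus gives way to one five-membered aromatic ring with 2 hetero atoms.

Within the data shown here, no measured step changes the group on that nitrogen alone, so direct evidence is lacking. Among the measured compounds shown here, the only measured step (a number 0.40 log units lower from compound 2 to compound 3 (beyond the scatter)) is an exchange of one group for another on an aromatic carbon, and it can serve only as a guide to size. It starts from the same compound and is modest, though beyond the scatter. With compound 2 at the top of the measured numbers, a fall of similar size seems the likeliest outcome. The expected step is a modest fall (a number 0.40 log units lower from compound 2 to compound 4 (beyond the scatter)). For compound 4 the estimated value is 3.6 (expected range 3.2 to 4).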

Compound 4, distribution coefficient: 2.9
Compound 4: the middle estimate sits 0.70 log units above what was measured; the measured number lies below the stated range.
By their numbers in this assay, from the lowest: compounds 1 and 4 (each within the scatter of the next); then compound 3; then compound 2.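

In this assay the sulfonamide nitrogen proves to be a position where one exchange of aromatic ring moves the number a long way: the step is a number 1.10 log units lower from compound 2 to compound 4 (beyond the scatter) and is large. The exchange on an aromatic carbon, by contrast, gave a number 0.40 log units lower from compound 2 to compound 3 (beyond the scatter) and is modest, so from the same starting compound the change on the sulfonamide nitrogen is the larger of the two steps. Nothing in the data given bears on the reason for the size of this step.

The single step also changes several things at once, since a six-membered ring carrying fluorine gives way to a five-membered ring with sulfur and a second nitrogen, and the compounds shown do not separate these; a pyridin-2-yl without the fluorine, or a simple methyl on the same nitrogen, would speak to that. From the compounds shown here alone, it also remains open whether 1,3-thiazol-2-yl in place of 6-fluoropyridin-2-yl would give a step of similar size with 1-methyl-1H-pyrazol-5-yl on the aromatic carbon, as in compound 3.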